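Two Spirooxindole Triazoles at the Assay Ceiling

The source may report more compounds than this note shows. Statements on the series, on what has been measured and on what is new or still open speak of the compounds shown alone.

In a functional assay on MCF7 cells (Homo sapiens) for antiproliferative activity, read by MTT assay, with a stated time of 48 h (on this read-out higher numbers stand for weaker inhibition and lower numbers for stronger inhibition), compound 1, `N#CC1=C(N)Oc2c(c3nc4ccccc4nc3c3ccccc23)C12C(=O)N(Cc1cnnn1-c1cc(Cl)ccc1Cl)c1ccccc12`, gives only a limit of > 50000 nM. Compound 2, `COc1ccc(-n2nncc2CN2C(=O)C3(C(C#N)=C(N)Oc4c(N)cc5nc6ccccc6nc5c43)c3ccccc32)cc1`, likewise gives only a limit of > 50000 nM in this assay. Compound 2 therefore stands at the same limit as compound 1, and neither value is a number; both sit where the limit of > 50000 nM in this assay, at which 2 of the 2 values shown sit, places them, so nothing here separates the two compounds or ranks them.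

Compound 3, `Cc1cc(C)c(-n2nncc2CN2C(=O)C3(C(C#N)=C(N)Oc4c(N)cc5nc6ccccc6nc5c43)c3ccccc32)c(C)c1`, has not yet been measured. It differs from compound 2 in one place: 2,4,6-trimethylphenyl in place of 4-methoxyphenyl on an aromatic nitrogen. The change swaps one six-membered aromatic ring of carbon only for another of the same kind on an aromatic nitrogen of the five-membered aromatic ring with three nitrogens, removing a single hydrogen-bond acceptor and adding one heavy atom.

With compound 2 at a limit in this assay, the author expects no step beyond the scatter, and the expected step from the one to the other, a step that the limit leaves unreadable from compound 2 to compound 3, is accordingly flat. For compound 3 the estimate in this assay is 60000 nM, with a range from 20000 nM to 200000 nM, most probably reported again as a limit rather than a number.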

Compound 3, half-maximal inhibitory concentration: > 50000 nM
Compound 3 gave a limit, no number; the forecaster's own chance of this, stated with the estimate: 85%; the middle value is on the limit's open side.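

In this assay compound 3 gives > 50000 nM, which is a limit and not a number. Compound 2 also stands at a limit, so no step can be read between compound 2 and compound 3. The compounds shown leave open whether 2,4,6-trimethylphenyl and 4-methoxyphenyl differ at all on this read-out.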